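The source may hold more compounds than are shown below. What is called first, only, known or untested is meant among the compounds shown, and "the series" means these compounds.

Compound 1 `COc1ccc(-n2c(=O)n(Cc3cc4cc(Cl)ccc4n3CCCC#N)c3cnccc32)cc1OC`, > 50000 nM in an ADME assay on HeLa cells (Homo sapiens) for cytotoxicity, read by ATP content, with a stated time of 3 days; a higher number here means that more compound is tolerated, a lower number that less compound is tolerated
Compound 2 `O=c1n(Cc2nc3ncccc3n2CCCCO)c2cnccc2n1C1CC1`, > 100000 nM in this assay

Both numbers are limits of this assay rather than measured values. Compound 1 stands at the limit described by the limit of > 50000 nM in this assay, at which 1 of the 2 values shown sits. Compound 2 stands at the limit described by the limit of > 100000 nM in this assay, at which 1 of the 2 values shown sits. Within the data shown here, no step between two measured compounds is available here, so the size of any change must be judged from the structures alone. Compound 3 `COc1ccc(-n2c(=O)n(Cc3cc4cc(Cl)ccc4n3CCCC#N)c3cnccc32)c(C)c1` differs from compound 1 in one place: 4-methoxy-2-methylphenyl in place of 3,4-dimethoxyphenyl on an aromatic nitrogen. The step that the limit leaves unreadable from compound 1 to compound 3 is expected to be none beyond the scatter, with compound 3 likely again reported as a limit. Compound 3 is estimated at 60000 nM, between 25000 nM and 150000 nM.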

Compound 3, half-maximal cytotoxic concentration: > 50000 nM
Compound 3: a limit, no number (the forecaster's own chance of this, stated with the estimate: 80%); the middle value lies beyond the limit too.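

Compound 1 and compound 3 are both reported only as limits, so no step between them can be read: the limit of > 50000 nM in this assay, at which 2 of the 3 values shown sit.

The compounds shown leave open what concentration, if any, would prove toxic to the cells in this assay.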